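Taking one methyl off a growth inhibitor

This account rests on a few compounds, and the source may have more. Where it says the series, first, only, none or still open, it means among the compounds named here.

In a functional assay on OVCAR-3 cells (Homo sapiens) (a lower number here means a stronger inhibitor of growth, a higher number a weaker inhibitor of growth), compound 1 `Oc1cc(-c2ccc(Cl)cc2)nc2ncccc12` gives 23400 nM and stands highest of the three measured compounds. Compound 3 `COc1cccc(-c2cc(O)c3cc(C)cnc3n2)c1` gives 41.7 nM at the low end. Compound 2 `COc1cccc(-c2cc(O)c3c(C)cc(C)nc3n2)c1` gives 251 nM as the second highest number, nearer to compound 3 than to compound 1, with both gaps beyond the scatter.

The step in question leads to compound 4 `COc1cccc(-c2cc(O)c3c(C)ccnc3n2)c1`, where hydrogen takes the place of methyl on an aromatic carbon next to the ring nitrogen hydrogen in place of methyl on an aromatic carbon in the shared core. For the measured compounds named here, no measured pair differs in only one place, so there is no direct precedent. Compound 3 at 41.7 nM also has hydrogen at that place, but it differs from compound 2 elsewhere too and is only a loose guide. A moderate shift to a lower number in this assay is therefore expected, though it may barely clear the scatter. The expected move is a 2.3-fold lower number from compound 2 to compound 4 (0.36 log units; beyond the scatter) by this estimate. For compound 4 the estimated value is 110 nM (range 30 nM to 400 nM).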

Compound 4, concentration for 50% growth inhibition: 25.7 nM
Compound 4: the middle estimate sits 4.3-fold (0.63 log units) above what was measured; measured number outside the range, below it.
By their numbers in this assay, from the lowest: compounds 4 and 3 (each within the scatter of the next); then compound 2; then compound 1.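

In this assay, for the compounds shown here, the step of a 9.8-fold lower number from compound 2 to compound 4 (0.99 log units; beyond the scatter) gives the first direct reading of a single change in this set, with hydrogen in place of methyl on an aromatic carbon next to the ring nitrogen. With everything else in the structure held constant, this pair shows that the methyl at this place is not required for strong growth inhibition, and that removing it gives a lower number by a margin beyond the scatter. Nothing available here bears on why the number falls when this methyl leaves.

As far as these compounds go, with only methyl and hydrogen seen at this place, it remains open how an ethyl group, a methoxy group, a chlorine atom or an amine would fare there. Going by these compounds alone, it is also open whether the same change would give a step of similar size in compounds carrying a different aryl group from the one shared by this pair.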